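A few compounds are considered here, and "the series" means these few. Any claim that something is new, unique, unknown or untested is made for them only; others in the source may bear on it.

The series shares one core, and two of its members have been measured in an assay on mitochondria from L6 cells (Rattus norvegicus) for activation, with a stated time of 90 min; a higher number here means that more compound is needed for the effect, a lower number that less compound is needed. Compound 1 `Cc1ccc(Nc2nc3nonc3nc2Nc2ccc(C)c(C)c2)cc1C` reaches only a limit of the assay, giving > 100000 nM in this assay. Within the data shown here, compound 2 `Fc1ccccc1Nc1nc2nonc2nc1NC1CCCCC1` gives 13400 nM in this assay, and it holds the only actual number so far. The other result, that of compound 1, is a limit (the limit of > 100000 nM in this assay, at which 1 of the 2 values shown sits).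

Compound 3 `Fc1ccccc1Nc1nc2nonc2nc1Nc1cccc(F)c1F` has not yet been measured in this assay. It differs from compound 2 in one place (2,3-difluorophenyl in place of cyclohexyl on a nitrogen on an aromatic ring), so 2,3-difluorophenyl now sits on the nitrogen on the aromatic ring where cyclohexyl sat. Among the measured compounds shown here, no step between two measured compounds is available to lean on, so the size and direction of the change from compound 2 to compound 3 are open; a modest gain is expected, a 4.5-fold lower number from compound 2 to compound 3 (0.65 log units; beyond the scatter). For compound 3 the estimate in this assay is 3000 nM, with a range from 500 nM to 30000 nM.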

Compound 3, half-maximal effective concentration: 500 nM
The estimate for compound 3 lay 6.0-fold (0.78 log units) above the measured number, and the stated range covers the measured number.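

Replacing cyclohexyl with 2,3-difluorophenyl gives a 27-fold lower number from compound 2 to compound 3 (1.43 log units; beyond the scatter) in this assay. Among these compounds, this is the first readable step, and it shows that the group on this nitrogen can change the number strongly, here towards less compound being needed. Nothing measured for these compounds accounts for the size of this step.

The change replaces a non-aromatic ring with an aromatic one and brings in two fluorine atoms at once, and the compounds shown do not separate these two parts. Going by these compounds, it remains open whether a plain phenyl ring would give the same gain, and whether a methoxy group or a carboxylic acid on the ring would keep it.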